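The compounds below may be only part of what the source reports. "The series", "measured", "known", "first", "only" and "open" are said of these compounds alone.

Among the measured compounds shown here, in a functional assay on SMMC-7721 cells (Homo sapiens) for cytotoxicity, read by MTT assay, with a stated time of 24 h (on this read-out higher numbers stand for weaker inhibition and lower numbers for stronger inhibition), compound 1 `CN1C/C(=C\c2ccncc2)C(=O)/C(=C/c2ccccc2F)C1` gives 7000 nM, the lowest number so far and therefore the strongest inhibition among the measured compounds. Compound 2 `CN1C/C(=C\c2ccncc2)C(=O)/C(=C/c2cc([N+](=O)[O-])ccc2F)C1` gives 14700 nM, and compound 3 `CN1C/C(=C\c2ccncc2)C(=O)/C(=C/c2ccc(F)cc2Br)C1` gives 23800 nM. The next structure, compound 4 `O=C1/C(=C/c2ccncc2)CNC/C1=C\c1ccccc1F`, differs from compound 1 at one place, with hydrogen in place of methyl on an amine nitrogen in a ring.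

Two measured steps offer some context: a 2.1-fold higher number from compound 1 to compound 2 (0.32 log units; beyond the scatter) and a 3.4-fold higher number from compound 1 to compound 3 (0.53 log units; beyond the scatter). Both are modest and both raise the number, but both alter the aromatic group, and neither touches the amine nitrogen. For the measured compounds named here, no measured pair tests the new change, so these steps suggest no direction and serve only as a rough guide to size. The expected result is a 1.1-fold higher number from compound 1 to compound 4 (0.06 log units; within the scatter), with no clear change beyond the usual scatter. For compound 4, the estimated value is 8000 nM, with an expected range from 2500 nM to 22000 nM.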

Compound 4, half-maximal inhibitory concentration: 18400 nM
Compound 4: middle estimate off by 2.3-fold (0.36 log units), on the low side; the range from low to high includes it.
By their numbers in this assay, from the lowest: compound 1; then compounds 2, 4 and 3 (each within the scatter of the next).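

The nitrogen in the ring is not a neutral spot in this assay: with hydrogen in place of methyl there, the result is a 2.6-fold higher number from compound 1 to compound 4 (0.42 log units; beyond the scatter), a modest step but one beyond the scatter, so of this pair the methyl compound gives the stronger inhibition. Among the compounds shown here, this is the only step that tests this position, as the changes leading to compound 2 and compound 3 altered only the aromatic group, and it shows that the amine nitrogen can shift the number too. No evidence at hand accounts for the rise.

The compounds shown carry only methyl or hydrogen on this nitrogen, so it remains open how an ethyl or benzyl group there would compare. As far as these compounds go, it is also open whether the same step would hold with the aromatic groups of compound 2 or compound 3.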